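The compounds below may be only part of what the source reports. "The series", "measured", "known", "first", "only" and "open" are said of these compounds alone.

Working notes on the series. Compound 1 `O=C(/C(=C\c1ccc(Cl)cc1)S(=O)(=O)c1ccc(Br)cc1)c1ccc(Br)cc1` and compound 2 `COc1ccc(/C=C(\C(=O)c2ccc(Br)cc2)S(=O)(=O)c2ccc(Br)cc2)cc1` differ by methoxy in place of chloro on an aromatic carbon. In a functional assay on DU-145 cells (Homo sapiens) for inhibition, read by trypan blue exclusion, with a stated time of 96 h (a higher number here means a weaker inhibitor of growth, a lower number a stronger inhibitor of growth), compound 1 gives 50000 nM and compound 2 gives 25000 nM; the step of a 2.0-fold lower number from compound 1 to compound 2 (0.30 log units; within the scatter) is within the scatter. Compound 3 `COc1ccc(C(=O)/C(=C\c2ccc(Cl)cc2)Sc2ccc(F)cc2)cc1` belongs to a core whose difference from the core of compound 1 is not broken down here. In this assay compound 3 sits at a limit of the assay, > 100000 nM, which is a limit and not a number (the limit of > 100000 nM in this assay, at which 1 of the 3 values shown sits). Compound 4 `COc1ccc(/C=C(/Sc2ccc(F)cc2)C(=O)c2ccc(OC)cc2)cc1` carries the same change as before, methoxy in place of chloro on an aromatic carbon. Because the earlier step of a 2.0-fold lower number from compound 1 to compound 2 (0.30 log units; within the scatter) was within the scatter, an expected step of a number no higher from compound 3 to compound 4 (the limit leaves the size open) of similar size is assumed, and compound 4 is expected near 100000 nM, estimated between 40000 nM and 300000 nM, with a fair chance that only a limit is reported.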

Compound 4, concentration for 50% growth inhibition: 25000 nM
The estimate for compound 4 lay 4.0-fold (0.60 log units) above the measured number; the whole stated range lies above it.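

The change from 4-chlorophenyl to 4-methoxyphenyl gives an at least 4.0-fold lower number from compound 3 to compound 4 (0.60 log units; beyond the scatter) in this assay. Compound 3 stands at > 100000 nM, which is a limit and not a number, so only a minimum size is known for this step. The step on the core of compound 3 lies beyond the scatter and the earlier step within it, but this does not show that the change carries differently from one core to the other: the same change on two cores in this assay, a 2.0-fold lower number (0.30 log units; within the scatter) from compound 1 to compound 2 and an at least 4.0-fold lower number (0.60 log units; beyond the scatter) from compound 3 to compound 4; the limit leaves it open whether they differ

From the compounds shown here alone, the true size of the step on the core of compound 3 remains open. Also open, going by these compounds, is how either core responds at this place to an amine, a carboxylic acid or a chain longer than methoxy.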